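Swapping a Cyclopropyl Ketone for a Diethyl Amide

A few compounds are considered here, and "the series" means these few. Any claim that something is new, unique, unknown or untested is made for them only; others in the source may bear on it.

Among the compounds with values here, compound 1 `CC1=C(C(=O)C2CC2)C(c2ccoc2)NC(=O)N1` stands highest of the two numbers measured so far: in an assay on membranes from HeLa cells for displacement of a labelled ligand from adenosine receptor A3 (Homo sapiens), read by scintillation counting, with a stated time of 180 min, tested at 1 uM (on this read-out higher numbers stand for more inhibition at the one concentration tested (going by the name of the read-out) and lower numbers for less inhibition), compound 1 gives 16%. Within the data shown here, its only measured neighbour, compound 2 `CC1=C(C(=O)C2CC2)C(c2ccsc2)NC(=O)N1`, carries a thiophen-3-yl in place of furan-3-yl on a saturated ring carbon; in this assay compound 2 gives 1%, a step of a number 15 percentage points lower from compound 1 to compound 2 (beyond the scatter). Compound 3 `CCN(CC)C(=O)C1=C(C)NC(=O)NC1c1ccoc1` keeps the furan-3-yl of compound 1 and changes the other side of the shared core instead: diethylamino in place of cyclopropyl on a carbonyl carbon. Among the measured compounds shown here, no measured step touches this carbonyl carbon. For the measured compounds named here, the single step available, from compound 1 to compound 2, alters a different place, so it offers no guide to direction or size here. The expectation for compound 3 is therefore a step of about a number 4 percentage points lower from compound 1 to compound 3 (within the scatter), not beyond the scatter, with a wide range reflecting the absence of any comparable measured change. Compound 3 is estimated to give 12%, with a range from 0% to 35%.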

Compound 3, a percentage reported as inhibition, at one concentration (the size of the read-out at that concentration, not a potency): 37%
Compound 3: middle estimate off by 25 percentage points, on the low side; measured number outside the range, above it.
By their numbers in this assay, from the lowest: compound 2; then compound 1; then compound 3.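

Diethylamino in place of cyclopropyl on a carbonyl carbon gives, in this assay, a number 21 percentage points higher from compound 1 to compound 3 (beyond the scatter). Within the data shown here, this is the only measured step at this place, and it shows that the read-out responds to what sits on the carbonyl carbon, and that a group with no ring, containing a nitrogen, can give a higher number here than cyclopropyl does. Nothing measured on these compounds accounts for the rise.

The step removes the ring, brings in a nitrogen and adds heavy atoms all at once, and the compounds shown do not separate these changes. They also leave open how a dimethylamino or pyrrolidin-1-yl group would read on this carbonyl carbon, and whether thiophen-3-yl in place of furan-3-yl would lower the number with diethylamino present, as it does with cyclopropyl.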